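Diethylamino in place of allylamino: notes on compound 3

The source may report more compounds than this note shows. Statements on the series, on what has been measured and on what is new or still open speak of the compounds shown alone.

Values in a functional assay for inhibition, with Homo sapiens as the target; on this read-out higher numbers stand for an effect only at larger amounts of compound and lower numbers for an effect already at smaller amounts:
- compound 1 `O=C1CCC(c2ccc(NC(=O)CCCl)cc2)=NN1`: 0.98 ug/mL
- compound 2 `C=CCNCC(=O)Nc1ccc(C2=NNC(=O)CC2)cc1`: about 21.5 ug/mL

Compound 2 stands highest of the two measured compounds, with compound 1 nearest. Compound 3 `CCN(CC)CC(=O)Nc1ccc(C2=NNC(=O)CC2)cc1` carries this change: diethylamino in place of allylamino on a saturated chain carbon bound to a carbonyl carbon; diethylamino replaces allylamino on a saturated chain carbon bound to a carbonyl carbon. Among the compounds with values here, the only measured step at this place (a 22-fold higher number from compound 1 to compound 2 (1.34 log units; beyond the scatter)) was large and beyond the scatter, but it replaced chloromethyl. Within the data shown here, no measured step joins two amino groups, so only a small change is expected. In this assay the expected 1.1-fold lower number from compound 2 to compound 3 (0.03 log units; within the scatter) lies within the scatter. The estimate for compound 3 is 20 ug/mL (expected range 6 ug/mL to 65 ug/mL).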

Compound 3, half-maximal effective concentration: about 10 ug/mL
For compound 3 the middle estimate is 2.0-fold (0.30 log units) above the measured one; the range from low to high includes it.
By their numbers in this assay, from the lowest: compound 1; then compound 3; then compound 2.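

In this assay, within the data shown here, the one step joining two amino groups at this place gives a 2.2-fold lower number from compound 2 to compound 3 (0.33 log units; beyond the scatter) and so the exchange of allylamino for diethylamino is modest yet beyond the scatter. Chloromethyl still stands well apart from diethylamino with a 10-fold higher number from compound 1 to compound 3 (1.01 log units; beyond the scatter) and both amino compounds carry higher numbers than compound 1. Nothing at hand bears on what lies behind either step.

Open, from the compounds shown here alone, is how a morpholine ring or an unsubstituted amine would read at this place. Also open, going by these compounds, is whether a longer chain carrying the diethylamino group would bring the number closer to that of compound 1.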